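This account rests on a few compounds, and the source may have more. Where it says the series, first, only, none or still open, it means among the compounds named here.

Compound 1 `Cc1ccc2nc(C(=O)Nc3c(F)cc(-c4cccc(F)c4)cc3F)c(C)c(O)c2c1` gives 0.98% in a functional assay on Hep 3B2 cells (Homo sapiens) for antiproliferative activity, read by MTT assay, with a stated time of 24 h, tested at 0.02 ug/mL; a lower number here means a weaker effect, a higher number a stronger effect of the compound at the concentration tested.
Compound 2 `Cc1c(C(=O)Nc2ccc(-c3ccccc3)cc2)nc2ccccc2c1O` gives 1.05% in this assay.
Compound 3 `Cc1ccc2nc(C(=O)Nc3c(F)cc(-c4cccc(F)c4)cc3F)c(C)c(C(=O)O)c2c1` gives 1.05% in this assay.

Compound 3 stands level with compound 2 at the digits shown, and together they are the highest of the three numbers, though all three lie within the scatter of one another, so none can be called stronger or weaker. Its nearest neighbour is compound 2, with no change at the digits shown; its furthest is compound 1. Among the measured compounds shown here, the only step between compounds differing in one place is a number 0.1 percentage points higher from compound 1 to compound 3 (within the scatter), within the scatter.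

Compound 4 `Cc1c(C(=O)Nc2c(F)cc(-c3cccc(F)c3)cc2F)nc2ccc(C(F)(F)F)cc2c1C(=O)O` differs from compound 3 by trifluoromethyl in place of methyl on an aromatic carbon. For the measured compounds named here, no measured step exchanges a methyl for a trifluoromethyl; the single step at hand, a number 0.1 percentage points higher from compound 1 to compound 3 (within the scatter), concerns another group and stayed within the scatter. With compound 1, compound 2 and compound 3 all near the bottom of this assay, the expected step is a number 0.1 percentage points lower from compound 3 to compound 4 (within the scatter), nothing beyond the scatter. Compound 4 is therefore estimated at 1%, expected between -8% and 10%.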

Compound 4, a percentage reported as inhibition, at one concentration (the size of the read-out at that concentration, not a potency): 1.15%
The estimate for compound 4 lay 0.2 percentage points below the measured number; low and high end bracket the measured number.
By their numbers in this assay, from the lowest: compounds 1, 2, 3 and 4 (each within the scatter of the next).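

Replacing methyl with trifluoromethyl on this aromatic carbon, meta to a fused ring and para to a fused ring, gives a number 0.1 percentage points higher from compound 3 to compound 4 (within the scatter) in this assay. Among the compounds shown here, this is the first step at this position on the shared core, and it shows that three added fluorine atoms leave the read-out within the scatter while all four compounds stay near the bottom of the assay. No available measurement gives a reason for this result.

With numbers this low, the step cannot show whether the same exchange would matter in a compound with a larger read-out. On these data alone, whether an amine, a carboxylic acid or a longer chain on this aromatic carbon would move the number beyond the scatter remains open.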